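Moving a Fluorine on the Phenyl Ring of a Trimethoxyphenyl Oxadiazoline

The source may report more compounds than this note shows. Statements on the series, on what has been measured and on what is new or still open speak of the compounds shown alone.

Measured so far:
Compound 1, `COc1cc(C2=NN(C(C)=O)C(c3ccccc3C(F)(F)F)O2)cc(OC)c1OC`: 15.2%
Compound 2, `COc1cc(C2=NN(C(C)=O)C(c3ccc(F)cc3)O2)cc(OC)c1OC`: 0.1%

Both compounds were tested in a functional assay on PC-3 cells (Homo sapiens) for antiproliferative activity, read by MTT assay, tested at 5 uM; on this read-out higher numbers stand for a stronger effect at the one concentration tested and lower numbers for a weaker effect. On those two numbers compound 2 stands lowest, its nearest neighbour being compound 1 at a higher value. For the measured compounds named here, the only measured step, a number 15.1 percentage points lower from compound 1 to compound 2 (beyond the scatter), changed both the kind of substituent and its place on the phenyl ring, so it bears only loosely on the move now considered. Compound 3, `COc1cc(C2=NN(C(C)=O)C(c3ccccc3F)O2)cc(OC)c1OC`, differs from compound 2 by 2-fluorophenyl in place of 4-fluorophenyl on a saturated ring carbon. Going by the values given here, since compound 1, which carries its substituent at the 2-position, gave the higher value, a small rise is plausible, but the single step available does not separate the effect of the position from that of the group. The expected step is therefore small, a number 7.9 percentage points higher from compound 2 to compound 3 (within the scatter), and need not exceed the scatter. Compound 3 is estimated at 8%, between 0% and 25%.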

Compound 3, a percentage reported as inhibition, at one concentration (the size of the read-out at that concentration, not a potency): 31.6%
For compound 3 the middle estimate is 23.6 percentage points below the measured one; the whole stated range lies below it.
By their numbers in this assay, from the lowest: compound 2; then compound 1; then compound 3.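

Keeping the fluorine and changing only where it sits on the phenyl ring, 2-fluorophenyl in place of 4-fluorophenyl gives in this assay a number 31.5 percentage points higher from compound 2 to compound 3 (beyond the scatter), so placement alone moves this read-out, something the earlier step could not show because it changed group and placement together. With the placement held, fluoro in place of trifluoromethyl gives a number 16.4 percentage points higher from compound 1 to compound 3 (beyond the scatter), so the identity of the group counts as well, and of these two groups, fluoro gives the higher number. Nothing available explains either shift.

As far as these compounds go, whether a chloro group, a methoxy group or an amine in place of the fluoro of 2-fluorophenyl would raise or lower the number remains open. All three readings come from a single concentration, so they leave the potency of these compounds open too.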